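Methyl on the ring nitrogen: notes toward compound 4

A few compounds are considered here, and "the series" means these few. Any claim that something is new, unique, unknown or untested is made for them only; others in the source may bear on it.

Measured so far in an assay on isolated protein for inhibition of MAP kinase-activated protein kinase 5 (Homo sapiens), read by mobility shift assay, tested at 30 uM; a lower number here means less inhibition, a higher number more inhibition at the concentration tested (going by the name of the read-out):
compound 1, `COc1ccc(-c2cc3[nH]nc(N)c3c(=O)[nH]2)cc1`: compound 1 gives 7%
compound 2, `Cc1cc2[nH]nc(N)c2c(N2CCCCC2)n1`: compound 2 gives 10%
compound 3, `COc1ccc(-c2cc3c(c(N)nn3C)c(=O)[nH]2)cc1`: compound 3 gives 16%

Compound 3 differs from compound 1 by methyl in place of hydrogen on an aromatic nitrogen. This step gave a number 9 percentage points higher from compound 1 to compound 3 (within the scatter), so it left the read-out in this assay essentially where it was. The difference between the core of compound 1 and the core of compound 2 is not broken down here; their two values lie within the scatter of each other.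

Compound 4, `Cc1cc2c(c(N)nn2C)c(N2CCCCC2)n1`, is not yet measured. It differs from compound 2 by methyl in place of hydrogen on an aromatic nitrogen, the same change as that from compound 1 to compound 3. For the measured compounds named here, for compound 4 a step of about a number 5 percentage points higher from compound 2 to compound 4 (within the scatter) is expected in this assay, resting only on the single earlier instance, a number 9 percentage points higher from compound 1 to compound 3 (within the scatter). Compound 4 is therefore estimated at 15%, with a range from 3% to 30%.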

Compound 4, a percentage reported as inhibition, at one concentration (the size of the read-out at that concentration, not a potency): 17%
The estimate for compound 4 lay 2 percentage points below the measured number, within the range that was stated.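

In this assay methyl in place of hydrogen on an aromatic nitrogen gives a number 7 percentage points higher from compound 2 to compound 4 (within the scatter) on this second core, so here too the change leaves the read-out essentially where it was. That is all the pair shows: the change has no step beyond the scatter on either core, which does not show that the methyl adds inhibition on either, nor that it would behave alike on a further core. Set side by side, the two steps do not differ: the same change on two cores in this assay, a number 9 percentage points higher (within the scatter) from compound 1 to compound 3 and a number 7 percentage points higher (within the scatter) from compound 2 to compound 4, 2 percentage points apart, within the scatter of two such steps

The compounds shown leave open whether a longer chain such as ethyl on that aromatic nitrogen would move the read-out beyond the scatter. They also leave open what a chain ending in an amine would do there.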